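Formyl-to-bromo swap on the aryl arm of the imidazopyrazine series

The compounds below may be only part of what the source reports. "The series", "measured", "known", "first", "only" and "open" are said of these compounds alone.

Measured compounds:
- compound 1, `O=Cc1ccc(-c2cn3ccnc3c(-c3ccc4ncn(C5CCCCC5)c4c3)n2)cc1`: 82.2%
- compound 2, `c1ccc2c(-c3cn4ccnc4c(-c4ccc5ncn(C6CCCCC6)c5c4)n3)cccc2c1`: 23%
- compound 3, `c1cn2cc(-c3ccsc3)nc(-c3ccc4ncn(C5CCCCC5)c4c3)c2n1`: 23.1%

In a functional assay on UO-31 cells (Homo sapiens) for inhibition, read by sulforhodamine B assay, with a stated time of 48 h, tested at 10 uM (on this read-out lower numbers stand for less inhibition and higher numbers for more inhibition at the one concentration tested (going by the name of the read-out)), compound 1 gives the highest of the three numbers, and both measured steps away from it are large: a number 59.2 percentage points lower from compound 1 to compound 2 (beyond the scatter) and a number 59.1 percentage points lower from compound 1 to compound 3 (beyond the scatter). Compound 2 and compound 3 sit together, a number 0.1 percentage points higher from compound 2 to compound 3 (within the scatter).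

Compound 4, `Brc1ccc(-c2cn3ccnc3c(-c3ccc4ncn(C5CCCCC5)c4c3)n2)cc1`, is not yet measured. It differs from compound 1 by bromo in place of formyl on an aromatic carbon; cut one bond further out, the change reads 4-formylphenyl to 4-bromophenyl. Neither measured step matches this change: both replace the whole 4-formylphenyl with a different ring, whereas compound 4 keeps the phenyl and exchanges only the group on it. Those steps show that the arm is sensitive, so a loss against compound 1 is expected, though a smaller one than in the two ring swaps. The expected step is a number 37.2 percentage points lower from compound 1 to compound 4 (beyond the scatter). Compound 4 is estimated at 45%, within 10% to 85%.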

Compound 4, a percentage reported as inhibition, at one concentration (the size of the read-out at that concentration, not a potency): 42.9%
Beside the measured number, compound 4's estimate is 2.1 percentage points above it; the measured number falls inside the stated range.
By their numbers in this assay, from the lowest: compounds 2 and 3 (each within the scatter of the next); then compound 4; then compound 1.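

With the phenyl kept and only the group on it exchanged, this assay still gives a large drop (a number 39.3 percentage points lower from compound 1 to compound 4 (beyond the scatter)), so the high number of compound 1 depends on the formyl group and not on the phenyl alone. The phenyl arm without formyl is not equivalent to the other rings either: 4-bromophenyl reads above both ring swaps, with a number 19.8 percentage points higher from compound 3 to compound 4 (beyond the scatter) and a number 19.9 percentage points higher from compound 2 to compound 4 (beyond the scatter), both modest beside the loss of formyl. Nothing measured here explains the gap between formyl and bromo.

Open, on these data alone, is whether another group at the same carbon, such as a carboxylic acid, an acetyl group or an aminomethyl group, would hold the number of compound 1. Also open, as far as these compounds go, is whether a formyl group on the naphthalen-1-yl or thiophen-3-yl ring would raise those arms.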